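Methoxy in Place of Fluoro: An Expected Lipophilicity

The source may hold more compounds than are shown below. What is called first, only, known or untested is meant among the compounds shown, and "the series" means these compounds.

Compound 1, `O=C(CNc1ccc(F)cc1)Nc1nc2ccc(Cl)cc2s1`: 3.88
Compound 2, `Fc1ccc(/C=N/NC(=S)Nc2nc3ccc(Cl)cc3s2)cc1`: 5.22

Of the compounds shown here, two sharing one core have been measured in a physicochemical assay for lipophilicity, in phosphate buffer, measured as octanol-water partition; on this read-out higher numbers stand for higher lipophilicity and lower numbers for lower lipophilicity. Compound 2 stands highest of the two numbers: in this assay compound 2 gives 5.22, and the nearest number, that of compound 1, lies lower by a gap beyond the scatter. Compound 3 `COc1ccc(/C=N/NC(=S)Nc2nc3ccc(Cl)cc3s2)cc1` differs from compound 2 in a single place: methoxy in place of fluoro on an aromatic carbon. Among the measured compounds shown here, no step between two measured compounds isolates this change, so the numbers on hand do not fix its size. Compound 3 is expected to stay close to compound 2, with a small downward step, a number 0.22 log units lower from compound 2 to compound 3 (within the scatter), that may well lie within the scatter. The estimate for compound 3 in this assay is 5, with a range from 4.6 to 5.4.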

Compound 3, partition coefficient: 5.16
Compound 3: middle estimate off by 0.16 log units, on the low side, and the stated range covers the measured number.
By their numbers in this assay, from the lowest: compound 1; then compounds 3 and 2 (each within the scatter of the next).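

With compound 3, methoxy in place of fluoro on an aromatic carbon, para to a large group, can be read directly in this assay as a number 0.06 log units lower from compound 2 to compound 3 (within the scatter) on the shared core. At this place, the 4-fluorophenyl and 4-methoxyphenyl compounds therefore cannot be told apart on this read-out, even though methoxy brings a hydrogen-bond acceptor that fluoro does not. Nothing on hand gives a reason for this result.

Among the compounds shown here, a single step covers only this pair, so it remains open how an amine, a carboxylic acid or a longer chain at the same place would read. On these data alone, it also remains open whether methoxy in place of fluoro would give a similar step on the core of compound 1.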